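This account rests on a few compounds, and the source may have more. Where it says the series, first, only, none or still open, it means among the compounds named here.

Working notes on a small ester series sharing one core.

Compound 1 `CCOC(=O)/C=C/c1ccc(OC)c(OC(=O)c2nc(C)c(C)nc2C)c1` gives 60.1% in a functional assay on EA.hy 926 cells (Homo sapiens) for cytotoxicity, read by MTT assay, with stated times of 24 h and 12 h, tested at 25 uM; a lower number here means a weaker effect, a higher number a stronger effect of the compound at the concentration tested. Compound 3 `CCOC(=O)/C=C/c1cccc(OC(=O)c2nc(C)c(C)nc2C)c1` differs from compound 1 by hydrogen in place of methoxy on an aromatic carbon; this change produced a number 25.9 percentage points lower from compound 1 to compound 3 (beyond the scatter), and in this assay compound 3 reads 34.2%. Compound 2 `CCOC(=O)/C=C/c1cc(OC)ccc1OC(=O)c1nc(C)c(C)nc1C` is built from the same atoms as compound 1, joined differently; the difference between the two cores is not broken down here. In this assay compound 2 gives 23.4%, the lowest of the three numbers, with compound 3 nearest above it and compound 1 furthest above it.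

Compound 4 `CCOC(=O)/C=C/c1ccccc1OC(=O)c1nc(C)c(C)nc1C` is not yet measured. It differs from compound 2 by hydrogen in place of methoxy on an aromatic carbon. This is the same kind of change as that from compound 1 to compound 3, but not the same: in compound 1 the methoxy sat ortho to a large group and para to the 2-(ethoxycarbonyl)ethenyl group, whereas in compound 2 it sits meta to the 2-(ethoxycarbonyl)ethenyl group and para to a large group. For the measured compounds named here, only one step of this kind is measured, so its transfer to the new place is uncertain.

A smaller step is expected here, a number 11.4 percentage points lower from compound 2 to compound 4 (beyond the scatter), since compound 2 already starts at 23.4% and the read-out has little room left to fall. Compound 4 is expected to give 12% in this assay, estimated to lie between 2% and 28%.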

Compound 4, a percentage reported as activity, at one concentration (the size of the read-out at that concentration, not a potency): 17.8%
For compound 4 the middle estimate is 5.8 percentage points below the measured one, and the stated range covers the measured number.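

In this assay, hydrogen in place of methoxy on an aromatic carbon gives a number 5.6 percentage points lower from compound 2 to compound 4 (within the scatter), and the size of this step does not carry over from the core of compound 1 to the core of compound 2: the same change on two cores in this assay, a number 25.9 percentage points lower (beyond the scatter) from compound 1 to compound 3 and a number 5.6 percentage points lower (within the scatter) from compound 2 to compound 4, 20.3 percentage points apart, beyond the scatter of two such steps

A step read on one of these two arrangements therefore cannot be added as a fixed amount on the other, and the value of the methoxy change depends on which of the two cores carries it. What this does not show is why the two steps part, and with a single pair on each core it gives no rule for any further core, nor a direction for the change on the core of compound 2, where the step stays within the scatter.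

The compounds shown leave open what other groups would do in the place of the methoxy, such as a hydroxyl, a chlorine or an amine, on either core. They also leave open whether a carboxylic acid or a longer chain at the ethyl ester end would follow the same dependence on the core.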